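Hydroxycarbamoyl to 2-(hydroxycarbamoyl)ethenyl on compound 1

This account rests on a few compounds, and the source may have more. Where it says the series, first, only, none or still open, it means among the compounds named here.

In a functional assay on HeLa cells (Homo sapiens) for inhibition, read by MTT assay, with a stated time of 48 h (a higher number here means a weaker inhibitor, a lower number a stronger inhibitor), compound 1 `O=C(NO)c1ccc(Oc2no[n+]([O-])c2S(=O)(=O)c2ccccc2)cc1` gives 1730 nM and compound 2 `COc1cc(C(=O)NO)ccc1Oc1no[n+]([O-])c1S(=O)(=O)c1ccccc1` gives 2260 nM on the same part of the scale. Compound 3 `O=C(/C=C/c1ccc(Oc2no[n+]([O-])c2S(=O)(=O)c2ccccc2)cc1)NO` keeps the core of compound 1 and carries one change (2-(hydroxycarbamoyl)ethenyl in place of hydroxycarbamoyl on an aromatic carbon): 2-(hydroxycarbamoyl)ethenyl in place of hydroxycarbamoyl on an aromatic carbon. Among the measured compounds shown here, the only measured step (a 1.3-fold higher number from compound 1 to compound 2 (0.12 log units; within the scatter)) is methoxy in place of hydrogen, a different change that stays within the scatter. No step beyond the scatter is therefore expected in this assay and no direction is favoured, the estimated step being (a 1.0-fold lower number from compound 1 to compound 3 (0.01 log units; within the scatter)). The estimated value for compound 3 is 1700 nM (expected range 600 nM to 5000 nM).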

Compound 3, half-maximal inhibitory concentration: 10400 nM
The estimate for compound 3 lay 6.1-fold (0.79 log units) below the measured number; measured number outside the range, above it.
By their numbers in this assay, from the lowest: compounds 1 and 2 (each within the scatter of the next); then compound 3.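

In this assay this position, para to a large group, proves sensitive to the change: 2-(hydroxycarbamoyl)ethenyl in place of hydroxycarbamoyl gives a 6.0-fold higher number from compound 1 to compound 3 (0.78 log units; beyond the scatter), towards weaker inhibition. This is the only step shown that lies beyond the scatter, whereas the methoxy step on the same ring, a 1.3-fold higher number from compound 1 to compound 2 (0.12 log units; within the scatter), does not. Nothing measured here accounts for the step.

Still open, as far as these compounds go, is whether the step follows the added chain length or the double bond. A saturated ethyl chain ending in hydroxycarbamoyl would separate the two.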